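The source may report more compounds than this note shows. Statements on the series, on what has been measured and on what is new or still open speak of the compounds shown alone.

Measured compounds:
Compound 1, `CCOC(=O)C1=C(Nc2ccccc2)S/C(=C\c2ccccc2)C1=O`: in a functional assay on JAR cells (Homo sapiens) for inhibition, read by MTT assay, with a stated time of 72 h, tested at 10 uM (a higher number here means more inhibition at the concentration tested (going by the name of the read-out), a lower number less inhibition), compound 1 gives 20.3%.
Compound 2, `CCOC(=O)C1=C(Nc2ccccc2)S/C(=C\c2ccc(O)c(O)c2)C1=O`: in this assay compound 2 gives 48.7%.
Compound 3, `CCOC(=O)C1=C(Nc2ccccc2)S/C(=C\c2ccc([N+](=O)[O-])c(O)c2)C1=O`: in this assay compound 3 gives 51.2%.

Compound 2 stands second highest of these three numbers, with compound 3 nearest and compound 1 furthest. Compound 4, `CCOC(=O)C1=C(Nc2ccccc2)S/C(=C\c2ccc(Br)c(O)c2)C1=O`, differs from compound 2 by bromo in place of hydroxy on an aromatic carbon. The step most directly comparable, a number 2.5 percentage points higher from compound 2 to compound 3 (within the scatter), exchanged hydroxy for nitro on the same aromatic carbon and stayed within the scatter, whereas the larger step of a number 28.4 percentage points higher from compound 1 to compound 2 (beyond the scatter) came from introducing the 3,4-dihydroxyphenyl. A single exchange at that carbon is therefore expected to leave compound 4 close to compound 2 in this assay, a step of a number 0.7 percentage points lower from compound 2 to compound 4 (within the scatter) that is not expected to exceed the scatter. Compound 4 is estimated at 48%, within a range from 35% to 62%.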

Compound 4, a percentage reported as inhibition, at one concentration (the size of the read-out at that concentration, not a potency): 39.8%
Estimate against measurement, compound 4: 8.2 percentage points above; measured number inside the range.
By their numbers in this assay, from the lowest: compound 1; then compounds 4, 2 and 3 (each within the scatter of the next, the first and the last beyond it).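

In this assay, bromo at this carbon, with no hydrogen-bond donor or acceptor, gives a number 8.9 percentage points lower from compound 2 to compound 4 (within the scatter) and so does not separate from hydroxy. The same carbon now also shows a step beyond the scatter, a number 11.4 percentage points lower from compound 3 to compound 4 (beyond the scatter), while the substituted ring still keeps a gain over phenyl, a number 19.5 percentage points higher from compound 1 to compound 4 (beyond the scatter). Nothing available explains these steps. Still open, as far as these compounds go, is how an amine or a carboxylic acid would read at this carbon, and whether the neighbouring hydroxy is needed for bromo to give this number.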